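An Arylamino Group Replaces the Free Amine

The compounds below may be only part of what the source reports. "The series", "measured", "known", "first", "only" and "open" are said of these compounds alone.

Compound 2 `Cc1cc(N)c(S(C)(=O)=O)cc1C(=O)N=C(N)N` gives 16 nM in a functional assay for inhibition of sodium/hydrogen exchanger (Oryctolagus cuniculus); a higher number here means a weaker inhibitor, a lower number a stronger inhibitor. Among the compounds with values here, of the two compounds measured so far, compound 2 stands at the higher number, and its nearest neighbour is compound 1 `Cc1cc(C)c(S(C)(=O)=O)cc1C(=O)N=C(N)N` at 11 nM. Within the data shown here, the single step measured, a 1.5-fold higher number from compound 1 to compound 2 (0.16 log units; within the scatter), lies within the scatter, so the two compounds cannot be ranked against each other.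

Compound 3 `Cc1cc(Nc2cccc(Cl)c2)c(S(C)(=O)=O)cc1C(=O)N=C(N)N` differs from compound 2 by 3-chlorophenyl in place of hydrogen on a nitrogen on an aromatic ring. Among the measured compounds shown here, no measured step touches this nitrogen; the only step known, a 1.5-fold higher number from compound 1 to compound 2 (0.16 log units; within the scatter), exchanged the group on the aromatic carbon itself and was small. The change to compound 3 is far larger in size than anything measured, and the data give no direction for it.

Compound 3 is therefore expected to move only modestly, a 1.6-fold higher number from compound 2 to compound 3 (0.19 log units; within the scatter), toward a higher number in this assay . The estimated value of compound 3 is 25 nM, with a range from 8 nM to 80 nM.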

Compound 3, half-maximal inhibitory concentration: 33 nM
Compound 3: middle estimate off by 1.3-fold (0.12 log units), on the low side; measured number inside the range.
By their numbers in this assay, from the lowest: compounds 1 and 2 (each within the scatter of the next); then compound 3.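

The nitrogen on the aromatic ring accepts a far larger group than the earlier compounds had shown, and the price is small for its size: in this assay the 3-chlorophenyl gives a 2.1-fold higher number from compound 2 to compound 3 (0.31 log units; beyond the scatter) and so produces the first step beyond the scatter. Against the methyl group of the first compound, the (3-chlorophenyl)amino group gives a 3.0-fold higher number from compound 1 to compound 3 (0.48 log units; beyond the scatter) and leaves compound 3 the weakest of the three, though still a modest step away. Nothing measured on these compounds speaks to the cause of this rise.

The compounds shown leave open whether the rise belongs to the phenyl ring or to its chlorine, and whether the place of that chlorine matters. A plain phenyl, a 4-chlorophenyl or a small chain such as ethyl on this nitrogen would separate these readings.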